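The compounds below may be only part of what the source reports. "The series", "measured", "known", "first", "only" and "open" are said of these compounds alone.

Compound 1, `Cc1nn(C)c(Oc2ccc(I)cc2)c1/C=N\CCCCCOc1cc2oc(=O)cc(C)c2cc1Cl`, in a functional assay on SMMC-7721 cells (Homo sapiens) for antiproliferative activity, read by MTT assay, with a stated time of 72 h; a higher number here means a weaker inhibitor, a lower number a stronger inhibitor: > 25000 nM
Compound 2, `Cc1nn(C)c(Oc2ccccc2F)c1/C=N\CCCCCCOc1cc2oc(=O)cc(C)c2cc1Cl`, in this assay: > 25000 nM

Each of these two values is a limit of the assay rather than a number. Compound 2 therefore stands at the edge of what this assay reports, and compound 1 stands at the same edge, as both sit at the limit of > 25000 nM in this assay, at which 2 of the 2 values shown sit. Among the compounds with values here, nothing in these two values separates them, and no step between measured compounds can be drawn from them.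

Compound 3, `Cc1nn(C)c(Oc2cccc(F)c2F)c1/C=N\CCCCCCOc1cc2oc(=O)cc(C)c2cc1Cl`, differs from compound 2 by fluoro in place of hydrogen on an aromatic carbon, so that the 2-fluorophenoxy group becomes a 2,3-difluorophenoxy group. Within the data shown here, there is no measured step against which to weigh this change, so no direction can be read off. The expectation is for no step beyond the scatter, the added fluoro being a single heavy atom on an aromatic carbon.

The estimate for compound 3 implies a step that the limit leaves unreadable from compound 2 to compound 3, and it is expected to stay within the scatter. Compound 3 is expected to give 35000 nM in this assay, with a range from 10000 nM to 120000 nM, and most probably only a limit is reported again.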

Compound 3, half-maximal inhibitory concentration: 22800 nM
Estimate against measurement, compound 3: 1.5-fold (0.19 log units) above; measured number inside the range.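

In this assay, compound 3, with its 2,3-difluorophenoxy group, gives 22800 nM, which is a number rather than a limit, so this position on the aromatic ring can carry fluoro, ortho to a fluoro group, with a reading that falls inside what the assay reports. The change itself amounts to an at least 1.0-fold lower number from compound 2 to compound 3 (0.04 log units; that floor lies within the scatter), and nothing larger can be claimed for it. Only this floor can be read because compound 2 gives a limit and not a number: the limit of > 25000 nM in this assay, at which 2 of the 3 values shown sit.

Within the data shown here, compound 1 differs from compound 3 in more than one place, so no step involving it can be read, and the part played by the iodo group or by chain length stays undetermined. From the compounds shown here alone, it also remains open whether a chloro or methoxy group at this same aromatic carbon, or a longer chain joining the two ends of the molecule, would give a number that differs from compound 3 by more than the usual scatter.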